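Aryl variation at the carbonyl of the acylhydrazone series

A few compounds are considered here, and "the series" means these few. Any claim that something is new, unique, unknown or untested is made for them only; others in the source may bear on it.

Measured compounds:
compound 1, `CC(/C=N/Nc1ccc([N+](=O)[O-])cc1)=N\NC(=O)c1ccccc1`: > 12000 nM
compound 2, `COc1cc(C(=O)N/N=C(C)/C=N/Nc2ccc([N+](=O)[O-])cc2)ccc1O`: 5100 nM

Among the measured compounds shown here, in a functional assay on cells (Splenocyte, Mus musculus, strain BALB/c) for inhibition, read by scintillation counting and thymidine incorporation, with a stated time of 72 h (on this read-out higher numbers stand for weaker inhibition and lower numbers for stronger inhibition), compound 2 gives 5100 nM and is the only compound with a numerical value. For compound 1 the assay reports only a limit, (the limit of > 12000 nM in this assay, at which 1 of the 2 values shown sits). Compound 3, `COc1ccc(C(=O)N/N=C(C)/C=N/Nc2ccc([N+](=O)[O-])cc2)cc1`, is not yet measured. It differs from compound 2 by 4-methoxyphenyl in place of 4-hydroxy-3-methoxyphenyl on a carbonyl carbon. For the measured compounds named here, the only measured step bearing on this change is an at least 2.3-fold lower number from compound 1 to compound 2 (0.37 log units; beyond the scatter), which introduced the 4-hydroxy-3-methoxyphenyl group in place of phenyl. Compound 3 keeps the methoxy group but loses the hydroxyl, so it lies between compound 1 and compound 2 in structure; part of that gain is expected to be given back, and the step of a 1.8-fold higher number from compound 2 to compound 3 (0.25 log units; within the scatter) is expected to be towards a higher number, though a value close to compound 2 cannot be ruled out. Compound 3 is therefore estimated at 9000 nM, with a range from 4000 nM to 20000 nM.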

Compound 3, half-maximal inhibitory concentration: > 12000 nM
Compound 3: no number, only a limit (the forecaster's own chance of this, stated with the estimate: 40%); middle value at least 1.3-fold (0.12 log units) away from the limit.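

Among the compounds shown here, replacing 4-hydroxy-3-methoxyphenyl with 4-methoxyphenyl on the carbonyl carbon gives an at least 2.3-fold higher number from compound 2 to compound 3 (0.37 log units; beyond the scatter) in this assay and so removes the only numerical value. Compound 3 gives > 12000 nM as a limit and not a number, so the step from compound 1 to compound 3 cannot be read, and 4-methoxyphenyl shows no measurable gain over phenyl. The loss from compound 2 is therefore known only as a minimum, with the two other compounds sitting at the same limit: the limit of > 12000 nM in this assay, at which 2 of the 3 values shown sit.

The compounds shown leave open whether the hydroxyl alone accounts for the measurable inhibition of compound 2 or needs the methoxy group with it, a question that a 4-hydroxyphenyl group at this carbonyl carbon would address. On these data alone, how an amine or a carboxylic acid on this aryl group would read also remains open.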